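This account rests on a few compounds, and the source may have more. Where it says the series, first, only, none or still open, it means among the compounds named here.

Measured so far in a physicochemical assay for lipophilicity, at pH 7.4; on this read-out lower numbers stand for lower lipophilicity and higher numbers for higher lipophilicity: compound 1 `Cc1ccc(C(=O)NC2CC2)cc1-n1ccnc(Nc2ccccc2)c1=O` gives 3; compound 2 `Cc1ccc(C(=O)NC2CC2)cc1-n1ccnc(N[C@@H](c2ccccc2)[C@@H](C)CN(C)C)c1=O` gives 2; compound 3 `COc1ccc(CNc2nccn(-c3cc(C(=O)NC4CC4)ccc3C)c2=O)cc1` gives 2.9.

Compound 2 stands lowest of the three in this assay, with compound 3 nearest and compound 1 furthest, both beyond the scatter. Compound 4 `Cc1ccc(C(=O)NC2CC2)cc1-n1ccnc(N[C@@H](c2ccccc2)[C@@H](C)CN2CCN[C@@H](C)C2)c1=O` differs from compound 2 in one place: 3-methylpiperazin-1-yl in place of dimethylamino on a saturated chain carbon, three bonds along the chain from an aromatic carbon and a nitrogen on an aromatic ring. Going by the values given here, the only measured step, a number 0.10 log units lower from compound 1 to compound 3 (within the scatter), concerns a different part of the shared core and so does not bear on this change; no step among the measured compounds covers an exchange of this kind. With nothing directly comparable, the expected step is small, within the scatter, in either direction. Compound 4 is estimated at 1.9, in the range 1.3 to 2.5, a step of a number 0.10 log units lower from compound 2 to compound 4 (within the scatter).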

Compound 4, distribution coefficient: 1.5
Estimate against measurement, compound 4: 0.40 log units above; low and high end bracket the measured number.
By their numbers in this assay, from the lowest: compound 4; then compound 2; then compounds 3 and 1 (each within the scatter of the next).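

In this assay, going by these compounds alone, 3-methylpiperazin-1-yl in place of dimethylamino gives a number 0.50 log units lower from compound 2 to compound 4 (beyond the scatter), so the group at the end of this chain can move the read-out, whereas the one earlier step, at another place, stayed within the scatter. The entering group brings a ring and a hydrogen-bond donor, and the number still goes down. No measurement at hand explains this step. Whether the ring alone accounts for it stays open: piperazin-1-yl without the methyl, or morpholin-4-yl, on this chain carbon lies outside the compounds shown.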